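This account rests on a few compounds, and the source may have more. Where it says the series, first, only, none or still open, it means among the compounds named here.

In an assay on isolated protein for inhibition of RAC-alpha serine/threonine-protein kinase (Homo sapiens), tested at 30 uM (a lower number here means less inhibition, a higher number more inhibition at the concentration tested (going by the name of the read-out)), compound 1 `Cn1cnc2c(Nc3ccccc3)ncnc21` gives 0%, compound 2 `Fc1ccc(C[n+]2c[nH]c3ncncc32)cc1` gives 8% and compound 3 `Clc1ncnc2c1ncn2Cc1ccccc1` gives 0%. Compound 3 stands level with compound 1 at the digits shown, and its gap to compound 2 lies within the usual scatter, so all three numbers sit together near the floor of the read-out. Compound 4 `Fc1ccc(Cn2cnc3c(Cl)ncnc32)cc1` has not been measured in this assay. It differs from compound 3 in one place: fluoro in place of hydrogen on an aromatic carbon. Compound 2 already carries a fluoro group on a six-membered aromatic ring of carbon only and gives 8%, which offers no sign of a shift. Within the data shown here, no comparable step between measured compounds exists, so the step is expected to be none beyond the scatter, a number 3 percentage points higher from compound 3 to compound 4 (within the scatter). Compound 4 is therefore estimated at 3%, within 0% to 12%.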

Compound 4, a percentage reported as inhibition, at one concentration (the size of the read-out at that concentration, not a potency): 0%
Estimate against measurement, compound 4: 3 percentage points above; the range from low to high includes it.
By their numbers in this assay, from the lowest: compounds 1, 3, 4 and 2 (each within the scatter of the next).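

In this assay, fluoro in place of hydrogen on an aromatic carbon, para to a large group, gives no change at the digits printed from compound 3 to compound 4 (within the scatter). Among these compounds, this is the first direct reading of this position, as the earlier compounds offered no comparison differing in one place. Both compounds sit at the floor of the read-out, where a loss could not show, so the result speaks only for this pair, and nothing measured here bears on why the fluoro group leaves the number unmoved. On these data alone, whether fluoro at this position leaves the number level on a compound with a higher number remains open. So does whether an amine or a carboxylic acid at this place would lift the number off the floor.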